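Moving the Chlorine on the Sulfonamide Ring

The source may hold more compounds than are shown below. What is called first, only, known or untested is meant among the compounds shown, and "the series" means these compounds.

Measured compounds:
compound 1, `O=C(NCc1ccc(CNS(=O)(=O)c2ccccc2Cl)cc1)c1cccnc1`: 100 nM
compound 2, `COc1ccccc1C(=O)NCc1ccc(CNS(=O)(=O)c2ccc(F)cc2)cc1`: 100 nM
compound 3, `Cc1ccccc1C(=O)NCc1ccc(CNS(=O)(=O)c2ccccc2Cl)cc1`: 1000 nM

All three were tested in an assay on MDA-MB-231 cells for displacement of a labelled ligand from C-X-C chemokine receptor type 4 (Homo sapiens), read by fluorescence and microscopy, with stated times of 10 min and 30 min; on this read-out lower numbers stand for an effect already at smaller amounts and higher numbers for an effect only at larger amounts of compound. Compound 1 gives 100 nM, level at the digits shown with compound 2, which gives 100 nM; together they sit at the lowest number of the three. Compound 3 gives 1000 nM, and the step of a 10-fold higher number from compound 1 to compound 3 (1.00 log units; beyond the scatter) lies beyond the scatter, so on this read-out compound 3 needs more compound than compound 1 for the same effect.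

Compound 4, `O=C(NCc1ccc(CNS(=O)(=O)c2cccc(Cl)c2)cc1)c1cccnc1`, keeps every part of compound 1 except one: 3-chlorophenyl in place of 2-chlorophenyl on a sulfonyl sulfur. Among the measured compounds shown here, no measured step changes only this chlorophenyl group, so no step bears directly on it. Compound 2 differs from compound 1 in two places at once, and its value matching compound 1 cannot be split into the two changes. For the measured compounds named here, the one measured step, from compound 1 to compound 3, concerns the amide end and gives no guide here. Lacking evidence for a shift, compound 4 is expected to stay near compound 1, with a step of a 1.2-fold higher number from compound 1 to compound 4 (0.08 log units; within the scatter). Compound 4 is thus estimated at 120 nM, within 30 nM to 500 nM.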

Compound 4, effective concentration (reported as EC, without a stated level of effect): 100 nM
Estimate against measurement, compound 4: 1.2-fold (0.08 log units) above; the range from low to high includes it.
By their numbers in this assay, from the lowest: compounds 1, 2 and 4 (each within the scatter of the next); then compound 3.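

In this assay, among the compounds shown here, the change to 3-chlorophenyl in place of 2-chlorophenyl on a sulfonyl sulfur gives no change at the digits printed from compound 1 to compound 4 (within the scatter) and is the first direct reading of this group, since the earlier step concerned only the amide end. With the pyridin-3-yl amide kept, the chlorine can therefore sit in either of these two ring places without a change that this assay can detect, whereas the amide-end change gave a 10-fold higher number from compound 1 to compound 3 (1.00 log units; beyond the scatter) and went beyond the scatter. Nothing available here explains why these two chlorophenyl groups read alike.

From the compounds shown here alone, it remains open whether the same match would hold with the 2-methylphenyl amide end of compound 3. Also open, going by these compounds, is how this ring would respond if a carboxylic acid or an amine replaced the chlorine.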